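Propargyl Amide in Place of a Chloroanilide

The source may hold more compounds than are shown below. What is called first, only, known or untested is meant among the compounds shown, and "the series" means these compounds.

Compound 2 `COc1ccc2nc(C)cc(OCC(=O)Nc3ccc(Cl)cc3)c2c1` shares its core with compound 1 `COc1ccc2nc(C)cc(OCC(=O)Nc3ccccc3)c2c1`. Within the data shown here, in an ADME assay on HepG2 cells (Homo sapiens) for cytotoxicity, read by trypan blue exclusion, with a stated time of 48 h, in the presence of a further agent that is not named here (a higher number here means that more compound is tolerated, a lower number that less compound is tolerated), compound 2 gives 89900 nM, the only number recorded in this assay. In this assay compound 1 reaches only a limit, > 155000 nM, and the limit of > 155000 nM in this assay, at which 1 of the 2 values shown sits, describes where one of the two values sits. Among the measured compounds shown here, the step of an at least 1.7-fold lower number from compound 1 to compound 2 (0.23 log units; that floor lies within the scatter) is the sole measured step, and its floor lies within the scatter. Compound 3 `C#CCNC(=O)COc1cc(C)nc2ccc(OC)cc12` differs from compound 2 by propargyl in place of 4-chlorophenyl on an amide-type nitrogen. For the measured compounds named here, no measured step concerns an exchange of this kind on the amide-type nitrogen; the single measured step is the only guide, and it was small. Compound 3 is therefore expected to show a step of about a 1.2-fold higher number from compound 2 to compound 3 (0.09 log units; within the scatter) in this assay, nothing beyond the scatter. Compound 3 is estimated to give 110000 nM, with a range from 45000 nM to 270000 nM.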

Compound 3, half-maximal cytotoxic concentration: > 176000 nM
Compound 3 gave a limit, no number (the forecaster's own chance of this, stated with the estimate: 35%); middle value at least 1.6-fold (0.20 log units) away from the limit.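

In this assay compound 3 reaches only a limit, not a number: the limit of > 176000 nM in this assay, at which 1 of the 3 values shown sits.

On the amide-type nitrogen, the exchange of 4-chlorophenyl for propargyl gives an at least 1.9-fold higher number from compound 2 to compound 3 (0.29 log units; that floor lies within the scatter), so this first change away from an aromatic ring on that nitrogen brings no lower number, although the floor of the step does not clear the scatter. Compound 1 and compound 3 both stand as limits, and the step between them cannot be read.

Going by these compounds, how far compound 3 actually lies from compound 2 stays open, as does whether the chloro group on the aromatic ring matters at all in this measurement. Also open, on these data alone, is how the number would respond to a different group on this nitrogen, such as a longer chain ending in an amine or a carboxylic acid.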